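This account rests on a few compounds, and the source may have more. Where it says the series, first, only, none or still open, it means among the compounds named here.

Working notes on the series, read in a functional assay on MCF7 cells (Homo sapiens) for antiproliferative activity, read by MTT assay, with a stated time of 72 h; on this read-out higher numbers stand for weaker inhibition and lower numbers for stronger inhibition. Compound 1 `Nc1nc(N)c2cc(CSC(=S)N3CCN(c4ccccc4)CC3)ccc2n1` gives 2950 nM, compound 2 `COc1ccc(N2CCN(C(=S)SCc3ccc4nc(N)nc(N)c4c3)CC2)cc1` gives 1580 nM, and compound 3 `Cc1ccc(N2CCN(C(=S)SCc3ccc4nc(N)nc(N)c4c3)CC2)c(C)c1` gives 3120 nM. Compound 3 thus stands within the scatter of both other compounds, and these numbers set no order among the three.

The next compound to be read is compound 4 `Nc1nc(N)c2cc(CSC(=S)N3CCN(c4ccc(Cl)cc4)CC3)ccc2n1`. Its difference from compound 3 is 4-chlorophenyl in place of 2,4-dimethylphenyl on an amine nitrogen in a ring. In words, 4-chlorophenyl stands in place of 2,4-dimethylphenyl on an amine nitrogen in a ring.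

The measured steps that bear on this change all concern the group at that same place. They are a 1.9-fold lower number from compound 1 to compound 2 (0.27 log units; within the scatter), a 1.1-fold higher number from compound 1 to compound 3 (0.02 log units; within the scatter) and a 2.0-fold higher number from compound 2 to compound 3 (0.30 log units; within the scatter), and each lies within the scatter. Within the data shown here, no measured compound carries 4-chlorophenyl, so the data give no direct reading of this group. No step beyond the scatter is therefore expected in this assay, and the expected direction is only weakly defined. The estimated step, taken towards the middle of the three measured values, is a 1.2-fold lower number from compound 3 to compound 4 (0.10 log units; within the scatter). For compound 4 the expected value is 2500 nM, with an estimated range of 1200 nM to 5000 nM.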

Compound 4, half-maximal inhibitory concentration: 4880 nM
The estimate for compound 4 lay 2.0-fold (0.29 log units) below the measured number; low and high end bracket the measured number.
By their numbers in this assay, from the lowest: compounds 2, 1, 3 and 4 (each within the scatter of the next, the first and the last beyond it).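

In this assay, among these compounds, the group on the amine nitrogen in a ring now gives its first step beyond the scatter, a modest one, with chloro in place of methoxy on an aromatic carbon (a 3.1-fold higher number from compound 2 to compound 4 (0.49 log units; beyond the scatter)), whereas all the steps among the earlier compounds lay within it. The other two steps stay within the scatter, for chloro in place of hydrogen on an aromatic carbon (a 1.7-fold higher number from compound 1 to compound 4 (0.22 log units; within the scatter)) and for 4-chlorophenyl in place of 2,4-dimethylphenyl (a 1.6-fold higher number from compound 3 to compound 4 (0.19 log units; within the scatter)), so the 4-chlorophenyl compound separates only from the 4-methoxyphenyl compound and the whole reading at this position rests on that single pair. No measurement shown here offers an explanation for that separation.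

The compounds shown leave open whether the separation between methoxy and chloro would hold for other groups on the same aromatic ring, such as fluoro, nitrile, hydroxy or a carboxylic acid. They also leave open how this position would read with a benzyl group or a pyridine ring in place of the substituted phenyl on the amine nitrogen.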